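Swapping an aryl group on a thienopyrimidine sulfonamide series

This account rests on a few compounds, and the source may have more. Where it says the series, first, only, none or still open, it means among the compounds named here.

Four compounds share one core and differ in two places. Compound 1 `C=CS(=O)(=O)N1CCN(c2ncnc3sc(-c4ccc(C#N)cc4)cc23)CC1` carries a 4-cyanophenyl group; compound 2 `C=CS(=O)(=O)N1CCN(c2ncnc3sc(-c4ccc(OC)nc4)cc23)CC1` carries a 6-methoxypyridin-3-yl group instead; compound 3 `C=CS(=O)(=O)N1CCN(c2nc(OC[C@H]3CCCN3C)nc3sc(-c4ccc(C#N)cc4)cc23)CC1` keeps the 4-cyanophenyl group but adds a (1-methylpyrrolidin-2-yl)methoxy group; compound 4 `C=CS(=O)(=O)N1CCN(c2nc(OC[C@H]3CCCN3C)nc3sc(-c4ccc(OC)nc4)cc23)CC1` combines both changes.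

In a functional assay on MDA-MB-436 cells (Homo sapiens) for antiproliferative activity, read by MTT assay, with a stated time of 48 h (a higher number here means a weaker inhibitor, a lower number a stronger inhibitor), compound 1 gives 9170 nM, and compound 2 gives 11900 nM. The change between them is 6-methoxypyridin-3-yl in place of 4-cyanophenyl on an aromatic carbon and it made a 1.3-fold higher number from compound 1 to compound 2 (0.11 log units; within the scatter). Compound 3 gives 2290 nM, the lowest of the three measured numbers; adding the (1-methylpyrrolidin-2-yl)methoxy group gave a 4.0-fold lower number from compound 1 to compound 3 (0.60 log units; beyond the scatter).

Compound 4 is not yet measured. Its difference from compound 3 is 6-methoxypyridin-3-yl in place of 4-cyanophenyl on an aromatic carbon, the same change that turned compound 1 into compound 2, made at the same place. The two cores on which it is made differ by (1-methylpyrrolidin-2-yl)methoxy in place of hydrogen on an aromatic carbon. Since the change barely moved the number from compound 1 to compound 2, a step of about a 1.3-fold higher number from compound 3 to compound 4 (0.12 log units; within the scatter) is expected here as well, resting on the step of a 1.3-fold higher number from compound 1 to compound 2 (0.11 log units; within the scatter) and on compound 3 at 2290 nM. Compound 4 is therefore estimated to give about 3000 nM in this assay, most likely between 1500 nM and 6500 nM. This rests on a single earlier occurrence of the change, so the expectation is uncertain.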

Compound 4, half-maximal inhibitory concentration: 4980 nM
Compound 4: middle estimate off by 1.7-fold (0.22 log units), on the low side, within the range that was stated.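

In this assay, putting 6-methoxypyridin-3-yl in place of 4-cyanophenyl on the core that carries the (1-methylpyrrolidin-2-yl)methoxy group gives a 2.2-fold higher number from compound 3 to compound 4 (0.34 log units; beyond the scatter), and set beside its earlier occurrence, this swap carries over from one core to the other: the same change on two cores in this assay, a 1.3-fold higher number (0.11 log units; within the scatter) from compound 1 to compound 2 and a 2.2-fold higher number (0.34 log units; beyond the scatter) from compound 3 to compound 4, 1.7-fold (0.22 log units) apart, within the scatter of two such steps

Adding the (1-methylpyrrolidin-2-yl)methoxy group in the presence of 6-methoxypyridin-3-yl gives a 2.4-fold lower number from compound 2 to compound 4 (0.38 log units; beyond the scatter), and this change also carries over: the same change on two cores in this assay, a 4.0-fold lower number (0.60 log units; beyond the scatter) from compound 1 to compound 3 and a 2.4-fold lower number (0.38 log units; beyond the scatter) from compound 2 to compound 4, 1.7-fold (0.22 log units) apart, within the scatter of two such steps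

So, across these four compounds, each change acts about the same whichever form of the other group is present, but each comparison rests on only one pair of steps, and although one swap step lies within the scatter and the other beyond it, the gap between them is too small to show that the swap costs more on one core than on the other.

The compounds shown leave open whether this agreement extends to other groups on the aromatic carbon next to the ring sulfur, such as a phenyl ring carrying a carboxylic acid or an amine. They also leave open whether it would hold if a longer chain or a different amine replaced the (1-methylpyrrolidin-2-yl)methoxy group.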